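This account rests on a few compounds, and the source may have more. Where it says the series, first, only, none or still open, it means among the compounds named here.

The measured compounds in an assay on CHO cells for displacement of a labelled ligand from adenosine receptor A1 (Homo sapiens), read by scintillation counting, with a stated time of 90 min, in the presence of a further agent that is not named here; a lower number here means a stronger inhibitor, a higher number a weaker inhibitor:
Compound 1 `CCCn1c(=O)[nH]c2nc(-c3ccc(S(=O)(=O)N4CCN(c5cccc(Cl)c5)CC4)cc3)[nH]c2c1=O` gives > 1000 nM, a limit of the assay.
Compound 2 `CCCn1c(=O)[nH]c2nc(-c3ccc(S(=O)(=O)N4CCN(c5cccc(Br)c5)CC4)cc3)[nH]c2c1=O` gives > 1000 nM, also a limit.
Compound 3 `CCCn1c(=O)[nH]c2nc(-c3ccc(S(=O)(=O)N4CCN(C(C)c5ccccc5)CC4)cc3)[nH]c2c1=O` gives >= 1000 nM, again a limit.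

Compound 3 therefore stands only at a limit, and the two other values shown are limits too (the limit of > 1000 nM in this assay, at which 2 of the 3 values shown sit, (the limit of >= 1000 nM in this assay, at which 1 of the 3 values shown sits)). Compound 4 `CCCn1c(=O)[nH]c2nc(-c3ccc(S(=O)(=O)N4CCN(Cc5ccc(Br)c(F)c5)CC4)cc3)[nH]c2c1=O` differs from compound 3 by 4-bromo-3-fluorobenzyl in place of 1-phenylethyl on an amine nitrogen in a ring. Going by the values given here, the steps that bear on this ring nitrogen are a step that the two limits leave unreadable from compound 1 to compound 3 and a step that the two limits leave unreadable from compound 2 to compound 3, and since every value involved is a limit neither step has a readable size. Nothing in the measured steps therefore points away from the limit, and compound 4 is expected to remain near it in this assay, with an estimated step that the limit leaves unreadable from compound 3 to compound 4. For compound 4 the estimate is 1500 nM, in the range 600 nM to 5000 nM.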

Compound 4, inhibition constant: 326 nM
Compound 4: the middle estimate sits 4.6-fold (0.66 log units) above what was measured; measured number outside the range, below it.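

In this assay, compound 4 is the only compound shown with a value clear of the limits, and the change to 4-bromo-3-fluorobenzyl is read as an at least 3.0-fold lower number from compound 3 to compound 4 (0.48 log units; beyond the scatter), an at least 3.0-fold lower number from compound 2 to compound 4 (0.48 log units; beyond the scatter) and an at least 3.0-fold lower number from compound 1 to compound 4 (0.48 log units; beyond the scatter). Going by these compounds alone, this shows that a change on the amine nitrogen in the ring can move the number off the limits, which the earlier steps could not show, as none of them can be read. All three new steps start from limits, so each is a bound only: the limit of > 1000 nM in this assay, at which 2 of the 4 values shown sit.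

On these data alone, it remains open whether the unsubstituted benzyl or 4-methoxybenzyl on this nitrogen would behave like 4-bromo-3-fluorobenzyl. As far as these compounds go, the separate parts played by the bromine and the fluorine also remain open.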